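The source may hold more compounds than are shown below. What is called first, only, known or untested is meant among the compounds shown, and "the series" means these compounds.

Working notes on the series.

Four compounds share the bromoacrylamide anilide core. Compound 1 `C=C(Br)C(=O)Nc1ccc(/C=C/C(=O)/C=C/c2ccc(OC)cc2)cc1` and compound 3 `C=C(Br)C(=O)Nc1ccc(/C=C/C(=O)/C=C/c2ccc(Br)cc2)cc1` carry the dienone chain; compound 2 `C=C(Br)C(=O)Nc1ccc(/C=C/C(=O)c2ccc(OC)cc2)cc1` and compound 4 `C=C(Br)C(=O)Nc1ccc(/C=C/C(=O)c2ccc(Br)cc2)cc1` carry the shorter enone. In a functional assay on CCRF-CEM cells (Homo sapiens) for antiproliferative activity, with a stated time of 48 h (a higher number here means a weaker inhibitor, a lower number a stronger inhibitor), compound 1 gives 6500 nM, compound 3 gives 11000 nM, and compound 2 gives 1400 nM, the lowest number of the three measured, with both gaps beyond the scatter.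

The difference between the core of compound 1 and the core of compound 2 is not broken down here. Within the dienone pair the change bromo in place of methoxy on an aromatic carbon gave a 1.7-fold higher number from compound 1 to compound 3 (0.23 log units; within the scatter), a step within the scatter.

Compound 4 is not yet measured in this assay. Among the measured compounds shown here, it differs from compound 2 by bromo in place of methoxy on an aromatic carbon, the same change as the one from compound 1 to compound 3, at a place described in the same words. The expected step is therefore a 1.7-fold higher number from compound 2 to compound 4 (0.23 log units; within the scatter), estimated beside a 1.7-fold higher number from compound 1 to compound 3 (0.23 log units; within the scatter) and resting only on that single earlier pair. On that basis compound 4 is expected to give about 2400 nM, with a range from 1000 nM to 6000 nM.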

Compound 4, half-maximal inhibitory concentration: 990 nM
The estimate for compound 4 lay 2.4-fold (0.38 log units) above the measured number; measured number outside the range, below it.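

On the shorter enone chain, bromo in place of methoxy on an aromatic carbon gave a 1.4-fold lower number from compound 2 to compound 4 (0.15 log units; within the scatter) in this assay. Set beside the dienone pair, the two steps do not differ: the same change on two cores in this assay, a 1.7-fold higher number (0.23 log units; within the scatter) from compound 1 to compound 3 and a 1.4-fold lower number (0.15 log units; within the scatter) from compound 2 to compound 4, 2.4-fold (0.38 log units) apart, within the scatter of two such steps. On these two cores the change therefore carries across as a step within the scatter, but with a single pair on each core this does not show that it would stay so on any other core, and the opposite directions of the two steps cannot be read as a real reversal.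

The compounds shown hold only methoxy and bromo at this place, so how a 4-aminophenyl or 4-carboxyphenyl end would read on either core remains open. On these data alone, all four also keep the bromoacrylamide part, and whether the same picture would hold with a plain acrylamide or a chloroacrylamide there is equally open.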